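A Smaller Aryl Amide on a Shared Core

A few compounds are considered here, and "the series" means these few. Any claim that something is new, unique, unknown or untested is made for them only; others in the source may bear on it.

Of the compounds shown here, three built on one shared core have been measured in a functional assay on A375P cells (Homo sapiens) for antiproliferative activity, read by MTT assay, with a stated time of 48 h; on this read-out lower numbers stand for stronger inhibition and higher numbers for weaker inhibition. Compound 1 (`COc1ccc(C(=O)Nc2cccc(-c3ccnc4c(N)cccc34)c2)cc1OC`) gives 9500 nM in this assay, the highest of the three numbers. Compound 2 (`Nc1cccc2c(-c3cccc(NC(=O)c4ccc(Cl)c(C(F)(F)F)c4)c3)ccnc12`) gives 1400 nM, and compound 3 (`Nc1cccc2c(-c3cccc(NC(=O)c4cc(C(F)(F)F)cc(C(F)(F)F)c4)c3)ccnc12`) gives 3400 nM; both numbers lie below that of compound 1 by more than the scatter. Compound 4 (`Cc1cc(C(=O)Nc2cccc(-c3ccnc4c(N)cccc34)c2)c(C)o1`) has not been measured. It differs from compound 1 in one place: 2,5-dimethylfuran-3-yl in place of 3,4-dimethoxyphenyl on a carbonyl carbon. Among the compounds with values here, no pair of measured compounds shows this change, so the expected step rests on the standing of compound 1 alone. The step expected from this change, a 1.3-fold higher number from compound 1 to compound 4 (0.10 log units; within the scatter), is small, toward a higher number, or none beyond the scatter. Compound 4 is expected to give 12000 nM in this assay, within 4000 nM to 40000 nM.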

Compound 4, half-maximal inhibitory concentration: > 20000 nM
Compound 4 ended at the assay's limit (the forecaster's own chance of this, stated with the estimate: 20%); middle value at least 1.6-fold (0.22 log units) from the limit.
By their numbers in this assay, from the lowest: compound 2; then compound 3; then compound 1. At a limit, above all of these: compound 4.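

Compound 4 gives > 20000 nM in this assay, which is a limit of the assay and not a number. Even so, replacing 3,4-dimethoxyphenyl with 2,5-dimethylfuran-3-yl on a carbonyl carbon gives an at least 2.1-fold higher number from compound 1 to compound 4 (0.32 log units; beyond the scatter). Within the data shown here, this is the first single-place step, and it shows that this position responds to a change of ring, even starting from the weakest of the three earlier numbers.

Going by these compounds, how far compound 4 lies beyond its limit remains open. So does whether a furan without the two methyl groups, or a pyridine, would fare differently at this position.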